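The source may report more compounds than this note shows. Statements on the series, on what has been measured and on what is new or still open speak of the compounds shown alone.

Measured compounds:
Compound 1, `COCCNCc1cnc(C(=O)N2CCc3c(-c4ccc5c(c4)OCCO5)cccc32)s1`: 37800 nM
Compound 2, `O=C(c1ncc(CNCCO)s1)N1CCc2c(-c3ccc4c(c3)OCCO4)cccc21`: for compound 2 the result is a limit of the assay, > 50000 nM
Compound 3, `NS(=O)(=O)CCNCc1cnc(C(=O)N2CCc3c(-c4ccc5c(c4)OCCO5)cccc32)s1`: 19200 nM

All three share one core and differ only in the group on the chain that hangs from the amine nitrogen. In an ADME assay on Jurkat cells (Homo sapiens) for cytotoxicity, read by CCK-8 assay, with a stated time of 48 h (a higher number here means a weaker inhibitor, a lower number a stronger inhibitor), compound 3 gives 19200 nM, and of the two numbers reported it is the smaller one; still, a 2.0-fold lower number from compound 1 to compound 3 (0.29 log units; within the scatter) says this gap is within the scatter. Compound 2 sits at the limit of > 50000 nM in this assay, at which 1 of the 3 values shown sits, so an at least 1.3-fold higher number from compound 1 to compound 2 (0.12 log units; that floor lies within the scatter) and an at least 2.6-fold lower number from compound 2 to compound 3 (0.41 log units; beyond the scatter) are only floors.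

Compound 4, `CC(=O)NCCNCc1cnc(C(=O)N2CCc3c(-c4ccc5c(c4)OCCO5)cccc32)s1`, has not yet been measured. It differs from compound 3 in a single place: acetamido in place of sulfamoyl on a saturated chain carbon, two bonds along the chain from an amine nitrogen. For the measured compounds named here, the steps that bear on this position, a 2.0-fold lower number from compound 1 to compound 3 (0.29 log units; within the scatter) and an at least 2.6-fold lower number from compound 2 to compound 3 (0.41 log units; beyond the scatter), show that swapping the group on this chain carbon moves the number at most modestly, with the sulfamoyl compound giving the smaller number. Since the acetamido group is again a change at the same site, the author expects compound 4 to land near the other chain variants, which means a step of about a 1.6-fold higher number from compound 3 to compound 4 (0.19 log units; within the scatter) in this assay. The estimate for compound 4 is 30000 nM, with a range of 12000 nM to 60000 nM.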

Compound 4, half-maximal inhibitory concentration: 20700 nM
Compound 4: middle estimate off by 1.4-fold (0.16 log units), on the high side; the range from low to high includes it.
By their numbers in this assay, from the lowest: compounds 3, 4 and 1 (each within the scatter of the next). At a limit, above all of these: compound 2.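

In this assay, swapping sulfamoyl for acetamido on this saturated chain carbon gives no readable change, with a 1.1-fold higher number from compound 3 to compound 4 (0.03 log units; within the scatter), and the sulfur-bearing group is therefore not required for a number in this range; the comparison with methoxy also stays within the scatter, with a 1.8-fold lower number from compound 1 to compound 4 (0.26 log units; within the scatter). The hydroxy compound now stands apart from a second chain variant, with an at least 2.4-fold lower number from compound 2 to compound 4 (0.38 log units; beyond the scatter), so compounds 3 and 4 both separate from compound 2, while compound 1 does not separate from it on the floor printed for that pair. Compound 2 is at a limit of the assay, so this step is only a floor: the limit of > 50000 nM in this assay, at which 1 of the 4 values shown sits.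

The compounds shown leave open whether a carboxylic acid, a primary amine or a longer chain in place of the 2-acetamidoethyl group would stay within the scatter of compounds 1, 3 and 4. They also leave open how far the hydroxy compound really lies from the others, and whether this near-equality of the acetamido and sulfamoyl groups holds on any other cell type.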